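A few compounds are considered here, and "the series" means these few. Any claim that something is new, unique, unknown or untested is made for them only; others in the source may bear on it.

Measured so far in a functional assay on MCF7 cells (Homo sapiens) for antiproliferative activity, read by MTT assay, with a stated time of 72 h; a lower number here means a stronger inhibitor, a higher number a weaker inhibitor: compound 1 `CCCSc1nc(N/N=C/c2c(O)ccc3ccccc23)c2nnn(Cc3ccccc3)c2n1`, 6400 nM; compound 2 `CCCSc1nc(N/N=C/c2ccc([N+](=O)[O-])cc2)c2nnn(Cc3ccccc3)c2n1`, 11000 nM.

Compound 2 holds the highest of the two numbers in this assay; compound 1 is its nearest neighbour, and the step of a 1.7-fold higher number from compound 1 to compound 2 (0.24 log units; within the scatter) places the two within the scatter of each other.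

Compound 3 `CCCSc1nc(N/N=C/c2ccc3ccccc3c2)c2nnn(Cc3ccccc3)c2n1` has not yet been measured in this assay. It differs from compound 2 in one place: naphthalen-2-yl in place of 4-nitrophenyl on a carbon with a double bond to nitrogen. Going by the values given here, the only measured step touching the same carbon, a 1.7-fold higher number from compound 1 to compound 2 (0.24 log units; within the scatter), stayed within the scatter, and it also exchanged one aromatic group for another there. Nothing in the series shows such an exchange moving the number beyond the scatter, so a step of no more than the scatter is expected, with no firm direction. On this basis compound 3 is estimated at 7500 nM (range 3000 nM to 18000 nM), which would mean an expected step of a 1.5-fold lower number from compound 2 to compound 3 (0.17 log units; within the scatter).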

Compound 3, half-maximal inhibitory concentration: > 64000 nM
Compound 3: no number, only a limit; the forecaster's own chance of this, stated with the estimate: 10%; middle value at least 8.5-fold (0.93 log units) away from the limit.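

In this assay compound 3 gives no number, only a limit of the assay: the limit of > 64000 nM in this assay, at which 1 of the 3 values shown sits.

The aromatic group on the carbon with a double bond to nitrogen can therefore move the read-out beyond the scatter, which the earlier pair did not show: naphthalen-2-yl in place of 4-nitrophenyl gives an at least 5.8-fold higher number from compound 2 to compound 3 (0.76 log units; beyond the scatter), and naphthalen-2-yl in place of 2-hydroxynaphthalen-1-yl gives an at least 10-fold higher number from compound 1 to compound 3 (1.00 log units; beyond the scatter). Two six-membered aromatic rings alone do not fix the outcome, as compound 1 also carries them and gives 6400 nM.

The compounds shown do not separate the hydroxy group from the point of attachment on the naphthalene as the source of the second step. Also open, on these data alone, is how naphthalen-1-yl without a hydroxy group, or naphthalen-2-yl bearing an amine or a carboxylic acid, would read in this assay.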